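This account rests on a few compounds, and the source may have more. Where it says the series, first, only, none or still open, it means among the compounds named here.

Of the compounds shown here, three that share one core have been tested in a functional assay on the whole organism (strain Swiss Albino) for inhibition, with Mus musculus as the target, read by paw edema, with a stated time of 180 min, at a dose of 100 mg/kg by the oral route; a higher number here means more inhibition at the dose given (going by the name of the read-out), a lower number less inhibition. Compound 1 `CNC(=S)N1N=C(c2ccc(C)cc2)CC1c1ccc[nH]1` gives 11.2%. Compound 2 `CCNC(=S)N1N=C(c2ccc(C)cc2)CC1c1ccc[nH]1` gives 10.5%. Compound 3 `CCCNC(=S)N1N=C(c2ccc(C)cc2)CC1c1ccc[nH]1` gives 20.9%.

Compound 2 holds the lowest of the three numbers, though that ranking is thin: its nearest neighbour is compound 1, and the step of a number 0.7 percentage points lower from compound 1 to compound 2 (within the scatter) lies within the scatter, so those two cannot be told apart. Among the compounds with values here, the one step from compound 2 that does stand out is a number 10.4 percentage points higher from compound 2 to compound 3 (beyond the scatter), a modest rise when a methyl is added two bonds along the chain from the amide-type nitrogen. All three measured steps, a number 0.7 percentage points lower from compound 1 to compound 2 (within the scatter), a number 9.7 percentage points higher from compound 1 to compound 3 (within the scatter) and a number 10.4 percentage points higher from compound 2 to compound 3 (beyond the scatter), concern only the length of that chain on the thiourea nitrogen.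

Compound 4 `CCNC(=S)N1N=C(c2ccc(OC)cc2)CC1c1ccc[nH]1` keeps the ethyl chain of compound 2 and instead changes the six-membered aromatic ring: methoxy in place of methyl on an aromatic carbon. Within the data shown here, no measured step touches that ring, so nothing here speaks to the size or direction of the change; two of the three steps seen were within the scatter anyway. The plain expectation is therefore a step of a number 1.5 percentage points higher from compound 2 to compound 4 (within the scatter) that does not rise beyond the scatter, leaving compound 4 near compound 2. Compound 4 is estimated to give 12%, within a range from 2% to 25%.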

Compound 4, a percentage reported as inhibition, in the whole organism at one dose (the size of the read-out at that dose, not a potency): 22.7%
Estimate against measurement, compound 4: 10.7 percentage points below, and the stated range covers the measured number.
By their numbers in this assay, from the lowest: compounds 2, 1, 3 and 4 (each within the scatter of the next, the first and the last beyond it).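

Within the data shown here, this is the first change to the six-membered aromatic ring, and it shows that the group on an aromatic carbon, para to a large group, matters in this assay: methoxy in place of methyl gives a number 12.2 percentage points higher from compound 2 to compound 4 (beyond the scatter). Among these compounds, until now, the only step from compound 2 beyond the scatter came from lengthening the chain on the thiourea nitrogen, so the ring substituent is a second place where a small edit gives a modest change, here with the ethyl chain held constant. Methoxy adds an oxygen and a hydrogen-bond acceptor to the methyl it replaces, but no measurement here separates these features or explains the rise.

The compounds shown leave open whether the oxygen itself is needed, which a comparison of methoxy with ethoxy, hydroxy or a chlorine atom at this place could begin to address. They also leave open whether methoxy would give a similar step alongside the propyl chain of compound 3, since the two changes are never combined here in one compound.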